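A Diethylaminoacetamide Side Chain Replaces a Phenol

The source may report more compounds than this note shows. Statements on the series, on what has been measured and on what is new or still open speak of the compounds shown alone.

The account follows a single change on a shared core, judged by an ADME assay on Vero cells (Chlorocebus sabaeus) for cytotoxicity; on this read-out higher numbers stand for lower toxicity in this test and lower numbers for higher toxicity in this test. Compound 1 `Oc1ccc(-c2nc3cc(C(F)(F)F)ccc3[nH]2)cc1` carries a hydroxy group on its pendant ring. In this assay compound 1 gives only a limit of the assay, > 100000 nM, and no number. Compound 2 `COc1cc(OC)cc(-c2nc3cc(C(F)(F)F)ccc3[nH]2)c1` is the second measured member. In this assay compound 2 likewise reaches only the limit, > 100000 nM. Compound 1 therefore stands at the ceiling of what the test reports, as described by the limit of > 100000 nM in this assay, at which 2 of the 2 values shown sit, and no difference between the two measured compounds can be read from these values.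

The unmeasured compound 3 `CCN(CC)CC(=O)Nc1ccc(-c2nc3cc(C(F)(F)F)ccc3[nH]2)cc1` differs from compound 1 as counted in (((diethylamino)methyl)carbonyl)amino in place of hydroxy on an aromatic carbon. No step between measured compounds exists to calibrate the effect of such a change, and nothing among the shown values ties any property to it.

The step of an at least 1.1-fold lower number from compound 1 to compound 3 (0.04 log units; that floor lies within the scatter) is expected to stay within the usual scatter. The author estimates for compound 3 a half-maximal cytotoxic concentration of 90000 nM, most plausibly between 25000 nM and 200000 nM, with a fair chance that this assay again reports only a limit.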

Compound 3, half-maximal cytotoxic concentration: 24000 nM
Compound 3: middle estimate off by 3.8-fold (0.57 log units), on the high side; measured number outside the range, below it.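

The change at this place is not silent: on an aromatic carbon, para to a large group, (((diethylamino)methyl)carbonyl)amino in place of hydroxy gives an at least 4.1-fold lower number from compound 1 to compound 3 (0.61 log units; beyond the scatter) in this assay, and the lower number stands for higher toxicity in this test. Compound 3 is therefore the first compound shown to give a number rather than a limit of the assay, which makes this position the first in the series with a readable effect on the read-out. The step is only a floor, and the real gap could be wider, because compound 1 sits at a limit of the assay: the limit of > 100000 nM in this assay, at which 2 of the 3 values shown sit.

The compounds shown leave open which part of the entering chain goes with the step, the diethylamino end or the carbonylamino link, and a plain acetylamino group or a dimethylaminoacetamide chain at the same place would tell these apart. They also leave open whether a chain with a piperidine in place of the diethylamino end, or a longer chain, would follow the same direction, since this single pair establishes no pattern.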